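Solubility notes: replacing the piperazinone side chain

The source may hold more compounds than are shown below. What is called first, only, known or untested is meant among the compounds shown, and "the series" means these compounds.

Measured so far in a physicochemical assay for solubility, read by HPLC, in phosphate buffer, at pH 6.5; on this read-out higher numbers stand for higher solubility and lower numbers for lower solubility:
compound 1 `COC(=O)C1=C(C)NC(c2nccs2)=NC1(C)c1ccc(OC)cc1` gives 106 ug/mL;
compound 2 `COC(=O)C1=C(C)NC(c2nccs2)=NC1(C)c1ccc(F)c(F)c1` gives 50 ug/mL;
compound 3 `COC(=O)C1=C(CN2CCNC(=O)C2)NC(c2nccs2)=NC1(C)c1ccc(F)cc1` gives 34 ug/mL.

Compound 3 holds the lowest of the three numbers. Its nearest neighbour is compound 2, whose value sits within the scatter of that of compound 3, so no order between these two can be read. Compound 1 lies furthest away, beyond the scatter, with the highest number of the set.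

For the measured compounds named here, the only single-point step among the measured compounds is a 2.1-fold lower number from compound 1 to compound 2 (0.33 log units; beyond the scatter), a change of the aryl group on the saturated ring carbon. It does not touch the side chain that is changed in the next compound.

Compound 4 `COC(=O)C1=C(COC(C(=O)O)C(F)(F)F)NC(c2nccs2)=NC1(C)c1ccc(F)cc1` differs from compound 3 as follows: a group of 9 heavy atoms (3 carbon, 3 oxygen, 3 fluorine; no ring) in place of a group of 7 heavy atoms (4 carbon, 2 nitrogen, 1 oxygen; one six-membered non-aromatic ring with 2 hetero atoms), on a saturated chain carbon bound to a double-bonded ring carbon. Going by the values given here, no measured step bears directly on this kind of exchange, so the expectation rests on the value of compound 3 alone and carries a wide range. The step of a 2.4-fold higher number from compound 3 to compound 4 (0.37 log units; beyond the scatter) is expected to be modest, upward, and not clearly beyond the scatter. Compound 4 is expected to give 80 ug/mL in this assay, with a range from 30 ug/mL to 220 ug/mL.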

Compound 4, solubility: > 649 ug/mL
Compound 4: only a limit was reported (the forecaster's own chance of this, stated with the estimate: 5%); at least 8.1-fold (0.90 log units) between middle value and limit.
By their numbers in this assay, from the lowest: compounds 3 and 2 (each within the scatter of the next); then compound 1. At a limit, above all of these: compound 4.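

For the compounds shown here, at the saturated chain carbon bound to a double-bonded ring carbon, the exchange of 3-oxopiperazin-1-yl for the open-chain group gives a large change in this assay, with an at least 19-fold higher number from compound 3 to compound 4 (1.28 log units; beyond the scatter), while the only earlier step, a 2.1-fold lower number from compound 1 to compound 2 (0.33 log units; beyond the scatter), lay on the aryl group and was modest. Going by these compounds alone, the side chain is therefore a place where this read-out can move much further than the one earlier aryl exchange did, although the counted hydrogen-bond donors, hydrogen-bond acceptors and net charge are the same for the leaving and the entering group, so those counts do not follow the step. For compound 4 the reading is a limit of the assay and not a number: the limit of > 649 ug/mL in this assay, at which 1 of the 4 values shown sits.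

As far as these compounds go, how much of the step belongs to the carboxylic acid, the trifluoromethyl group or the loss of the ring stays open, and an ether chain ending in a primary alcohol, or the same chain without the trifluoromethyl group, would begin to separate these parts. From the compounds shown here alone, whether the exchange carries the same weight alongside another aryl group, such as the 3,4-difluorophenyl of compound 2, also stays open.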